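A few compounds are considered here, and "the series" means these few. Any claim that something is new, unique, unknown or untested is made for them only; others in the source may bear on it.

Compound 1 `N#CC1=C(N)Oc2c(N)cc3nc4ccccc4nc3c2C12C(=O)N(Cc1cnnn1-c1cccc(C(F)(F)F)c1)c1ccccc12` gives in an ADME assay on L02 cells (Homo sapiens) for antiproliferative activity, read by MTT assay, with a stated time of 48 h (a lower number here means a stronger inhibitor, a higher number a weaker inhibitor), 38100 nM.
Compound 2 `CCOc1ccc(-n2nncc2CN2C(=O)C3(C(C#N)=C(N)Oc4c(N)cc5nc6ccccc6nc5c43)c3ccccc32)cc1` reaches in this assay only a limit of the assay, > 50000 nM.
Compound 3 `Cc1ccc(C)c(-n2nncc2CN2C(=O)C3(C(C#N)=C(N)Oc4c(N)cc5nc6ccccc6nc5c43)c3ccccc32)c1` likewise reaches in this assay only a limit of the assay, > 50000 nM.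

Compound 3 thus stands at the ceiling of what this assay reports, and no number can be placed on it; the same holds for compound 2 (the limit of > 50000 nM in this assay, at which 2 of the 3 values shown sit). Compound 4 `Cc1cc(C)cc(-n2nncc2CN2C(=O)C3(C(C#N)=C(N)Oc4c(N)cc5nc6ccccc6nc5c43)c3ccccc32)c1` has not yet been measured in this assay. Its change from compound 3 is 3,5-dimethylphenyl in place of 2,5-dimethylphenyl on an aromatic nitrogen. Among the measured compounds shown here, two measured steps touch the same aromatic nitrogen: an at least 1.3-fold higher number from compound 1 to compound 3 (0.11 log units; that floor lies within the scatter), and a step that the two limits leave unreadable from compound 2 to compound 3. Neither step reveals a readable effect of the aryl group on this position, and the only numbered point, compound 1, sits close to the limit itself. Compound 4 is therefore expected to remain at or near the limit of this assay, with a step that the limit leaves unreadable from compound 3 to compound 4 that is not expected to reach beyond the scatter. The estimate for compound 4 in this assay is 60000 nM, with a range from 25000 nM to 150000 nM.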

Compound 4, half-maximal inhibitory concentration: > 50000 nM
Compound 4 gave a limit, no number (the forecaster's own chance of this, stated with the estimate: 70%); the middle value is on the limit's open side.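

In this assay, 3,5-dimethylphenyl in place of 2,5-dimethylphenyl on the aromatic nitrogen gives compound 4 a limit rather than a number, so a second dimethylphenyl arrangement now ends at the ceiling and a third aryl group has joined the limit: the limit of > 50000 nM in this assay, at which 3 of the 4 values shown sit. The steps from compound 4 to compound 2 and from compound 3 to compound 4 cannot be read, since both ends of each are limits. The only step with a floor is an at least 1.3-fold higher number from compound 1 to compound 4 (0.11 log units; that floor lies within the scatter), so no effect of this change beyond the scatter is shown.

On these data alone, how far compounds 2, 3 and 4 lie beyond the limit stays unknown. Also open, as far as these compounds go, is whether an amine or a carboxylic acid on this phenyl ring would bring a readable number.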